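Chain extension on a bromodimethoxyphenyl dienone scaffold

The source may hold more compounds than are shown below. What is called first, only, known or untested is meant among the compounds shown, and "the series" means these compounds.

The measured compounds are:
compound 1, `COc1cc(/C=C2\CCC/C(=C\c3cccc([N+](=O)[O-])c3)C2=O)cc(Br)c1OC`, 16.7 ug/mL;
compound 2, `CCOc1c(Br)cc(/C=C2\CCC/C(=C\c3cccc([N+](=O)[O-])c3)C2=O)cc1OC`, 10.8 ug/mL;
compound 3, `CCOc1c(Br)cc(/C=C2\CCC/C(=C\c3ccc([N+](=O)[O-])cc3)C2=O)cc1OC`, 3.91 ug/mL.

In a functional assay on SK-N-MC cells (Homo sapiens) for cytotoxicity, read by MTT assay (a higher number here means a weaker inhibitor, a lower number a stronger inhibitor), the move from compound 1 to compound 2 is methyl in place of hydrogen on a saturated chain carbon bound to an oxygen on an aromatic ring, and it made a step of a 1.5-fold lower number from compound 1 to compound 2 (0.19 log units; within the scatter). Compound 3 gives the lowest number of the three; in this assay the step from compound 2 is a 2.8-fold lower number from compound 2 to compound 3 (0.44 log units; beyond the scatter). Compound 4, `CCCOc1c(Br)cc(/C=C2\CCC/C(=C\c3ccc([N+](=O)[O-])cc3)C2=O)cc1OC`, has not been measured. It differs from compound 3 by methyl in place of hydrogen on a saturated chain carbon, two bonds along the chain from an oxygen on an aromatic ring, which is the same kind of change as that from compound 1 to compound 2, though the place differs: bound to the oxygen in one case, two bonds along the chain from it in the other. The difference between the cores of compound 1 and compound 3 is not broken down here. Compound 4 is expected to give a step of a 1.3-fold lower number from compound 3 to compound 4 (0.12 log units; within the scatter), because the earlier step of a 1.5-fold lower number from compound 1 to compound 2 (0.19 log units; within the scatter) stayed within the scatter. Compound 4 is estimated at 3 ug/mL, between 1.5 ug/mL and 6.5 ug/mL.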

Compound 4, half-maximal inhibitory concentration: 23.3 ug/mL
Compound 4: middle estimate off by 7.8-fold (0.89 log units), on the low side, and the stated range ends below it.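

In this assay, the added methyl gave a 6.0-fold higher number from compound 3 to compound 4 (0.78 log units; beyond the scatter), and this step does not match the earlier one: the same change on two cores in this assay, a 1.5-fold lower number (0.19 log units; within the scatter) from compound 1 to compound 2 and a 6.0-fold higher number (0.78 log units; beyond the scatter) from compound 3 to compound 4, 9.2-fold (0.96 log units) apart, beyond the scatter of two such steps. The result of this change on the core of compound 1 therefore did not carry over to the core of compound 3. These steps do not show what sets them apart, as the cores differ and the methyl also sits in a different place, bound to the oxygen in one case and two bonds along the chain from it in the other.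

From the compounds shown here alone, it remains open whether propoxy would give a similar step with 3-nitrophenyl in place of 4-nitrophenyl. Going by these compounds, it is also open how a longer chain such as butoxy, or an amine in place of propoxy, would compare with compound 4.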